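A Methyl Added Twice in a Cytotoxicity Series

The compounds below may be only part of what the source reports. "The series", "measured", "known", "first", "only" and "open" are said of these compounds alone.

Three compounds have been tested in an ADME assay on MT4 cells (Homo sapiens) for cytotoxicity, read by MTT assay, with a stated time of 96 h; a lower number here means that less compound is tolerated, a higher number that more compound is tolerated:

compound 1 `Cc1ccc(/N=N/c2ccc(NCCCN(C)C)cc2)cc1`: 17000 nM
compound 2 `CN(C)CCCNc1ccc(/N=N/c2ccccc2)cc1`: 17000 nM
compound 3 `CN(C)CCCN(/N=N/c1ccccc1)c1ccccc1`: 33000 nM

Compound 1 and compound 2 share one core and differ only by a (methyl in place of hydrogen on an aromatic carbon); that change gave no change at the digits printed from compound 2 to compound 1 (within the scatter). Compound 3 has the same atoms as compound 2 joined differently, so its core is another one; the difference between the two cores is not broken down here, and the values of compound 2 and compound 3 are within the scatter of each other, as are those of compound 1 and compound 3.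

Compound 4 `Cc1ccc(/N=N/N(CCCN(C)C)c2ccccc2)cc1` has not yet been measured. It differs from compound 3 by a (methyl in place of hydrogen on an aromatic carbon), and the place of the new group is described in the same words as for the step from compound 2 to compound 1, so this is the same change made on the other core. Within the data shown here, with only one earlier example, the expectation rests on that single step: because the same change gave no change at the digits printed from compound 2 to compound 1 (within the scatter), the step of no change at the digits printed from compound 3 to compound 4 (within the scatter) is expected. Compound 4 is therefore estimated at 33000 nM in this assay, with a likely range from 15000 nM to 70000 nM.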

Compound 4, half-maximal cytotoxic concentration: 18000 nM
The estimate for compound 4 lay 1.8-fold (0.26 log units) above the measured number, and the stated range covers the measured number.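

In this assay, methyl in place of hydrogen on an aromatic carbon of compound 3 gave a 1.8-fold lower number from compound 3 to compound 4 (0.26 log units; within the scatter) as the step on the second core. In this series, then, the phenyl to 4-methylphenyl change carried from one core to the other without a difference that can be told from the ordinary spread of repeated measurements, though two pairs of compounds say nothing about any further core, and steps this small give no real size for the effect of the methyl. The two steps compare as follows: the same change on two cores in this assay, no change at the digits printed (within the scatter) from compound 2 to compound 1 and a 1.8-fold lower number (0.26 log units; within the scatter) from compound 3 to compound 4, 1.8-fold (0.26 log units) apart, within the scatter of two such steps.

What the compounds shown leave open is whether a group other than methyl in the same place, such as a methoxy group, a chlorine atom or a carboxylic acid, would also carry from one core to the other. Also open, on these data alone, is what a longer chain in place of the one ending in the dimethylamino group would do on either core.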